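The source may hold more compounds than are shown below. What is called first, only, known or untested is meant among the compounds shown, and "the series" means these compounds.

Of the compounds shown here, two sharing one core have so far been measured in an ADME assay on microsomes from liver (Homo sapiens) for metabolic stability, read by LC-MS, using NADPH, tested at 5 uM; on this read-out lower numbers stand for a shorter-lived compound and higher numbers for a longer-lived compound. Compound 1 `Cc1cc(-c2ccccc2)n(/C(N)=N/S(=O)(=O)c2cc(C)c(Cl)cc2SCc2ccccc2Cl)n1` gives 0.163 h in this assay, and compound 2 `Cc1cc(-c2ccccc2)n(/C(N)=N/S(=O)(=O)c2cc(C)c(Cl)cc2SCc2ccccc2)n1` gives 0.0938 h. For the measured compounds named here, the single step between them, a 1.7-fold lower number from compound 1 to compound 2 (0.24 log units; within the scatter), is the only one recorded, and it does not separate the two compounds. On the numbers shown, compound 2 therefore stands lowest of the two, its nearest neighbour being compound 1 at a distance that remains within the scatter.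

Compound 3 `Cc1ccc(CSc2cc(Cl)c(C)cc2S(=O)(=O)/N=C(\N)n2nc(C)cc2-c2ccccc2)cc1` is the next compound to be measured in this assay. It differs from compound 2 by methyl in place of hydrogen on an aromatic carbon. Going by the values given here, the one measured step that touches the same six-membered aromatic ring of carbon only, a 1.7-fold lower number from compound 1 to compound 2 (0.24 log units; within the scatter), was itself within the scatter, so there is no measured evidence that a small change on this ring moves the half-life beyond the usual variation. On that basis the step of a 1.1-fold higher number from compound 2 to compound 3 (0.03 log units; within the scatter) is expected to stay within the scatter, with no clear direction. The half-life of compound 3 in this assay is therefore estimated at 0.1 h, within a range of 0.045 h to 0.22 h.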

Compound 3, half-life: 0.176 h
Compound 3: middle estimate off by 1.8-fold (0.25 log units), on the low side, within the range that was stated.
By their numbers in this assay, from the lowest: compounds 2, 1 and 3 (each within the scatter of the next).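

For the compounds shown here, the 4-methylbenzyl compound gives the first reading of a group on this aromatic carbon, para to a large group, and in this assay the change from benzyl, a 1.9-fold higher number from compound 2 to compound 3 (0.27 log units; within the scatter), does not separate the two compounds. The exchange of 2-chlorophenyl for 4-methylphenyl on the saturated chain carbon bound to the sulfur, a 1.1-fold higher number from compound 1 to compound 3 (0.03 log units; within the scatter), does not separate its two compounds either, so neither a chloro nor a methyl on this ring gives a step beyond the scatter, whichever of the two places on the ring is involved. Nothing measured here on the compounds speaks to what lies behind these half-lives.

Open, going by these compounds, is whether a group of another kind at the same place, such as a methoxy, an amine or a carboxylic acid, would give a step beyond the scatter, or whether this ring tolerates such groups with as little effect as a methyl. Also open, on these data alone, is whether a change elsewhere on the shared core, for example on the benzyl chain carbon or in place of the sulfur, would move the half-life more clearly than these two substituents.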